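The source may hold more compounds than are shown below. What is called first, only, known or untested is meant among the compounds shown, and "the series" means these compounds.

Working notes on the series.

Compound 1 `O=C(/C=C/c1ccc2c(C(F)(F)F)cccc2n1)c1ccccn1` is the reference here. In an ADME assay on A549 cells (Homo sapiens) for cytotoxicity (a higher number here means a weaker inhibitor, a lower number a stronger inhibitor), compound 1 gives 43100 nM. Two pyridyl variants on the carbonyl carbon accompany it: compound 2 `O=C(/C=C/c1ccc2c(C(F)(F)F)cccc2n1)c1ccncc1`, which in this assay gives 45400 nM, and compound 3 `O=C(/C=C/c1ccc2c(C(F)(F)F)cccc2n1)c1cccnc1`. For compound 3 the read-out is a limit of the assay, > 50000 nM; this is the limit of > 50000 nM in this assay, at which 1 of the 3 values shown sits. The measured steps are all small: a 1.1-fold higher number from compound 1 to compound 2 (0.02 log units; within the scatter), an at least 1.1-fold higher number from compound 1 to compound 3 (0.06 log units; that floor lies within the scatter), and an at least 1.1-fold higher number from compound 2 to compound 3 (0.04 log units; that floor lies within the scatter). Compound 1 thus stands with the lowest of the two numbers, compound 2 being its nearest neighbour within the scatter, and compound 3 giving only a limit.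

The step to compound 4 `O=C(/C=C/c1ccc2ccccc2n1)c1ccccn1` is of a different kind: hydrogen in place of trifluoromethyl on an aromatic carbon. Going by the values given here, none of the measured steps touches this part of the core; all three swap the pyridyl on the carbonyl carbon, and none of them moves beyond the scatter. Nothing in the series therefore points to a sizeable step in this assay for the loss of the trifluoromethyl, in either direction, and the numbers seen so far all sit in the same weak range. The expectation is a step of a 1.0-fold lower number from compound 1 to compound 4 (0.00 log units; within the scatter), within the scatter. Compound 4 is estimated at 43000 nM, with a range from 18000 nM to 100000 nM.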

Compound 4, half-maximal inhibitory concentration: 18500 nM
Compound 4: the middle estimate sits 2.3-fold (0.37 log units) above what was measured, and the stated range covers the measured number.
By their numbers in this assay, from the lowest: compound 4; then compounds 1 and 2 (each within the scatter of the next). At a limit, above all of these: compound 3.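

Hydrogen in place of trifluoromethyl, on an aromatic carbon ortho to a fused ring and meta to a fused ring, gives in this assay a 2.3-fold lower number from compound 1 to compound 4 (0.37 log units; beyond the scatter), the only step in the series printed as beyond the scatter. Going by these compounds alone, the pyridyl swaps on the carbonyl carbon did not show this: those with two numbers stay within the scatter, and those ending at the limit of compound 3 have floors within it, so this position is the first place where a single change shifts the reading, towards a stronger inhibitor in this assay. The shift is modest and rests on one pair of compounds, and no measured property at hand bears on the reason for it.

The compounds shown hold only trifluoromethyl or hydrogen at this carbon, so it remains open whether a methyl group, a chlorine atom or a methoxy group there would read like hydrogen, like trifluoromethyl or like neither. From the compounds shown here alone, it also remains open whether the same step holds with pyridin-3-yl or pyridin-4-yl on the carbonyl carbon, since the hydrogen compound appears here with pyridin-2-yl alone.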